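Adding a Methyl to the Amine of Compound 3

The compounds below may be only part of what the source reports. "The series", "measured", "known", "first", "only" and "open" are said of these compounds alone.

Compound 3 `CNCc1nc2ccccc2c(-c2ccccc2)c1C(=O)NCc1cc(C(F)(F)F)cc(C(F)(F)F)c1` stands at the lowest number among the values shown: in an in vitro assay on UC11MG cells for binding affinity to Substance-P receptor (Homo sapiens), read by radioligand binding (on this read-out lower numbers stand for stronger inhibition and higher numbers for weaker inhibition), compound 3 gives 0.011 nM. Its nearest measured neighbour is compound 2 `O=C(NCc1cc(C(F)(F)F)cc(C(F)(F)F)c1)c1c(CCl)nc2ccccc2c1-c1ccccc1`, which in this assay gives 26 nM, and the step of a 2400-fold lower number from compound 2 to compound 3 (3.37 log units; beyond the scatter) is large. Compound 1 `O=C(NCc1cc(C(F)(F)F)cc(C(F)(F)F)c1)c1cnc2ccccc2c1-c1ccccc1` in this assay gives > 1000 nM, and this is a limit of the assay rather than a number (the limit of > 1000 nM in this assay, at which 1 of the 3 values shown sits). The steps of an at least 38-fold lower number from compound 1 to compound 2 (1.58 log units; beyond the scatter) and an at least 90000-fold lower number from compound 1 to compound 3 (4.95 log units; beyond the scatter) are both large.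

Compound 4 `CN(C)Cc1nc2ccccc2c(-c2ccccc2)c1C(=O)NCc1cc(C(F)(F)F)cc(C(F)(F)F)c1` differs from compound 3 in one place: methyl in place of hydrogen on an amine nitrogen. Going by the values given here, none of the measured steps alters this nitrogen once the amine is present. The step of a 2400-fold lower number from compound 2 to compound 3 (3.37 log units; beyond the scatter) shows how much the methylamino group was worth in place of chloro, but it says nothing about a second methyl on that nitrogen. With only methylamino turning into dimethylamino, no movement beyond the scatter is expected. Compound 4 is therefore estimated to give 0.02 nM, within a range from 0.003 nM to 0.15 nM. The expected step of a 1.8-fold higher number from compound 3 to compound 4 (0.26 log units; within the scatter) is thus estimated to sit within the usual scatter, in either direction.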

Compound 4, half-maximal inhibitory concentration: 0.22 nM
Compound 4: the middle estimate sits 11-fold (1.04 log units) below what was measured, outside the stated range (above it).
By their numbers in this assay, from the lowest: compound 3; then compound 4; then compound 2. At a limit, above all of these: compound 1.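

Going by these compounds alone, on this amine nitrogen a single added methyl matters: in this assay, turning methylamino into dimethylamino gives a 20-fold higher number from compound 3 to compound 4 (1.30 log units; beyond the scatter), so the nitrogen proves sensitive to this small change, which none of the earlier steps tested. The loss does not cancel the gain from the amine, since dimethylamino in place of chloro on the saturated chain carbon still gives a 120-fold lower number from compound 2 to compound 4 (2.07 log units; beyond the scatter), although this gain is smaller than the one seen with methylamino. Set against the core with only hydrogen on that aromatic carbon, (dimethylamino)methyl gives an at least 4500-fold lower number from compound 1 to compound 4 (3.65 log units; beyond the scatter), a step whose starting value is a limit of the assay and not a number: the limit of > 1000 nM in this assay, at which 1 of the 4 values shown sits.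

The compounds shown cannot separate the effect of adding the methyl from that of losing the hydrogen on the nitrogen, and they give no cause for the loss. An ethylamino group, which keeps that hydrogen while carrying a longer chain, a primary amine, or a ring amine such as morpholine on the same saturated chain carbon would show how far this trend extends.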